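Amide aryl variation on a shared chalcone-type core

This account rests on a few compounds, and the source may have more. Where it says the series, first, only, none or still open, it means among the compounds named here.

Measured compounds:
- compound 1, `Cc1nc(C)c(/C=C/C(=O)c2ccc(NC(=O)c3ccccc3F)cc2)nc1C`, 7390 nM
- compound 2, `COc1ccc(C(=O)Nc2ccc(C(=O)/C=C/c3nc(C)c(C)nc3C)cc2)cc1OC`, 5060 nM
- compound 3, `Cc1nc(C)c(/C=C/C(=O)c2ccc(NC(=O)c3ccc(F)cc3F)cc2)nc1C`, 2450 nM

Three compounds sharing one core and differing only in the aryl group on the amide carbonyl have been tested in a functional assay on A549 cells (Homo sapiens) for antiproliferative activity, read by CCK-8 assay, with a stated time of 72 h; a lower number here means a stronger inhibitor, a higher number a weaker inhibitor. Compound 3 gives the lowest number of the three; its nearest neighbour is compound 2 and the step of a 2.1-fold lower number from compound 2 to compound 3 (0.31 log units; beyond the scatter) lies beyond the scatter, as does the larger step of a 3.0-fold lower number from compound 1 to compound 3 (0.48 log units; beyond the scatter). Compound 1 and compound 2 sit close together, with a 1.5-fold lower number from compound 1 to compound 2 (0.16 log units; within the scatter).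

The next compound, compound 4, `COc1ccc(C(=O)Nc2ccc(C(=O)/C=C/c3nc(C)c(C)nc3C)cc2)cc1`, has not yet been measured in this assay. It differs from compound 3 by 4-methoxyphenyl in place of 2,4-difluorophenyl on a carbonyl carbon. Among the measured compounds shown here, two measured steps bear on this change. The move from a methoxy-bearing aryl to the difluorinated aryl, a 2.1-fold lower number from compound 2 to compound 3 (0.31 log units; beyond the scatter), was modest but beyond the scatter, and the removal of that aryl's added fluoro in reverse, a 3.0-fold lower number from compound 1 to compound 3 (0.48 log units; beyond the scatter), points the same way. Compound 4 carries a methoxy-bearing aryl without fluorine, so compound 4 is expected to return toward the numbers of compound 1 and compound 2, giving a step of about a 2.2-fold higher number from compound 3 to compound 4 (0.35 log units; beyond the scatter) in this assay. Compound 4 is therefore estimated at 5500 nM, within a range of 2500 nM to 12000 nM.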

Compound 4, half-maximal inhibitory concentration: 4150 nM
The estimate for compound 4 lay 1.3-fold (0.12 log units) above the measured number; the measured number falls inside the stated range.
By their numbers in this assay, from the lowest: compounds 3, 4, 2 and 1 (each within the scatter of the next, the first and the last beyond it).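

In this assay the exchange of 2,4-difluorophenyl for 4-methoxyphenyl on the carbonyl carbon gives a 1.7-fold higher number from compound 3 to compound 4 (0.23 log units; within the scatter) and so stays inside the scatter, which means compound 3 no longer stands clear of every other member of the set. Taking one methoxy away from the 3,4-dimethoxyphenyl group is equally unreadable (a 1.2-fold lower number from compound 2 to compound 4 (0.09 log units; within the scatter)), and so is the exchange of 2-fluorophenyl for 4-methoxyphenyl (a 1.8-fold lower number from compound 1 to compound 4 (0.25 log units; within the scatter)), leaving compound 1, compound 2 and compound 4 together as one group that this assay does not separate. Nothing in the data speaks to what lies behind these numbers.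

Going by these compounds, compound 3 stands beyond the scatter from compound 1 and compound 2 but not from compound 4, so whether the 2,4-difluorophenyl group holds a real edge over every other aryl group here stays open. The aryl groups shown carry only fluoro and methoxy, so it also remains open how the number would move with an amine or a carboxylic acid on that ring, or with a longer chain in its place.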